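The source may report more compounds than this note shows. Statements on the series, on what has been measured and on what is new or still open speak of the compounds shown alone.

In an ADME assay on MDBK cells (Bos taurus) for cytotoxicity, read by MTT assay (on this read-out lower numbers stand for higher toxicity in this test and higher numbers for lower toxicity in this test), compound 1 `OC[C@@H]1[C@@H](O)[C@H](O)[C@@H](O)CN1CCCCCCOc1cc(F)ccc1F` reads > 500000 nM, which is a limit of the assay and not a number. Among the measured compounds shown here, compound 2 `OC[C@@H]1[C@@H](O)[C@H](O)[C@@H](O)CN1CCCCCCOc1cc(Cl)ccc1Cl` gives 320000 nM, the only actual number so far. For the measured compounds named here, the single measured step, an at least 1.5-fold lower number from compound 1 to compound 2 (0.19 log units; that floor lies within the scatter), places 2,5-dichlorophenyl where 2,5-difluorophenyl stood, on an oxygen on a saturated carbon. Compound 3 `CC1CCC(OCCCCCCN2C[C@H](O)[C@@H](O)[C@H](O)[C@H]2CO)CC1C` keeps the shared core and changes the same place: a group of 8 heavy atoms (8 carbon; one six-membered non-aromatic ring of carbon only) in place of a group of 8 heavy atoms (6 carbon, 2 chlorine; one six-membered aromatic ring of carbon only), on an oxygen on a saturated carbon. Going by the values given here, only that one step bears on this change, and it is a different exchange whose floor lies within the scatter, so it offers no firm direction. No step beyond the scatter is therefore expected in this assay. The expected step is a 1.3-fold lower number from compound 2 to compound 3 (0.11 log units; within the scatter), estimated to stay within the scatter. For compound 3 the estimated value is 250000 nM, with an expected range from 90000 nM to 500000 nM.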

Compound 3, half-maximal cytotoxic concentration: > 500000 nM
Compound 3: a limit, no number (the forecaster's own chance of this, stated with the estimate: 30%); middle value at least 2.0-fold (0.30 log units) from the limit.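

In this assay, among the compounds shown here, compound 3, with its six-membered non-aromatic carbon ring on the oxygen, reads at a limit of the assay and not at a number, so the only actual number still belongs to compound 2. The change gives an at least 1.5-fold higher number from compound 2 to compound 3 (0.19 log units; that floor lies within the scatter), which sets a floor and no size, while the step from compound 1 to compound 3 joins two limits and cannot be read. The position now reaches the limit with both an aromatic and a non-aromatic ring on the oxygen: the limit of > 500000 nM in this assay, at which 2 of the 3 values shown sit.

The compounds shown leave open how far compound 1 and compound 3 actually lie from compound 2. They also leave open whether an amine or a carboxylic acid on this ring, or a longer chain, would give a number below the limit.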